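Replacing 2-methoxyphenyl in compound 3

The source may hold more compounds than are shown below. What is called first, only, known or untested is meant among the compounds shown, and "the series" means these compounds.

Values measured in a functional assay on MCF7 cells (Homo sapiens) for cytotoxicity, read by MTT assay, with a stated time of 96 h; on this read-out higher numbers stand for weaker inhibition and lower numbers for stronger inhibition:
compound 1 `COc1cc(C(=O)c2cn(-c3ccccc3)cc2-c2ccccc2C)cc(OC)c1OC`: 190 nM
compound 2 `COc1cc(C(=O)c2cn(-c3ccccc3)cc2-c2cccc(Cl)c2)cc(OC)c1OC`: 540 nM
compound 3 `COc1ccccc1-c1cn(-c2ccccc2)cc1C(=O)c1cc(OC)c(OC)c(OC)c1`: 190 nM

Compound 3 stands level with compound 1, and together they hold the lowest of the three numbers. The data show no change at the digits printed from compound 1 to compound 3 (within the scatter), and they also show a 2.8-fold lower number from compound 2 to compound 3 (0.45 log units; beyond the scatter).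

Compound 4 `COc1cc(C(=O)c2cn(-c3ccccc3)cc2-c2cc(F)ccc2F)cc(OC)c1OC` has not yet been measured. It carries 2,5-difluorophenyl in place of 2-methoxyphenyl on an aromatic carbon of a five-membered aromatic ring with 1 nitrogen (2,5-difluorophenyl in place of 2-methoxyphenyl on an aromatic carbon). All three measured compounds differ from one another at this same place, so their steps are the ones that bear on the change. Within the data shown here, the swap between 2-methylphenyl and 2-methoxyphenyl gave no step beyond the scatter, whereas the one step away from these groups that can be read here is modest, at a 2.8-fold higher number from compound 1 to compound 2 (0.45 log units; beyond the scatter). Among the measured compounds shown here, no measured compound carries fluorine at this place, so the data cannot fix the direction firmly.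

In this assay, a modest rise at most is therefore expected, with compound 2 as the guide to its size at 540 nM. The estimated step is a 1.5-fold higher number from compound 3 to compound 4 (0.17 log units; within the scatter). For compound 4 the expected value is 280 nM, with an estimated range of 100 nM to 750 nM.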

Compound 4, half-maximal inhibitory concentration: 230 nM
Estimate against measurement, compound 4: 1.2-fold (0.09 log units) above; measured number inside the range.
By their numbers in this assay, from the lowest: compounds 1, 3 and 4 (each within the scatter of the next); then compound 2.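

In this assay, among these compounds, fluorine now appears at this place for the first time, and 2,5-difluorophenyl, which carries no oxygen, reads like the two groups already at the low end of the series (a 1.2-fold higher number from compound 3 to compound 4 (0.08 log units; within the scatter); a 1.2-fold higher number from compound 1 to compound 4 (0.08 log units; within the scatter)). The same group stands clearly apart from 3-chlorophenyl (a 2.3-fold lower number from compound 2 to compound 4 (0.37 log units; beyond the scatter)), so compound 2 is now the only one of the four beyond the scatter of the others. Among the compounds shown here, the three groups with a substituent numbered 2 in their name, on compounds 1, 3 and 4, thus lie within the scatter of one another, and compound 2, the one group without such a substituent, goes against any wider reading of that pattern.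

No measurement at hand accounts for these numbers. The compounds shown leave open whether the position of the substituent or the chlorine itself sets compound 2 apart, which 2-chlorophenyl or 3-fluorophenyl could separate, and how a phenyl bearing an amine or a carboxylic acid at this place would read.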